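The source may hold more compounds than are shown below. What is called first, only, known or untested is meant among the compounds shown, and "the series" means these compounds.

Compound 1 `CS(=O)(=O)N1C(=O)COC12C=CC(=O)C=C2`: > 10000 nM
Compound 2 `Cc1ccccc1S(=O)(=O)N1C(=O)COC12C=CC(=O)C=C2`: > 10000 nM
Compound 3 `O=C1C=CC2(C=C1)OCC(=O)N2S(=O)(=O)c1ccccc1OC(F)(F)F`: > 10000 nM

All three entries come from a functional assay on MDA-MB-231 cells (Homo sapiens) for inhibition, read by sulforhodamine B assay, with a stated time of 74 h (a lower number here means a stronger inhibitor, a higher number a weaker inhibitor), and each is a limit of the assay, not a number. Compound 2 stands only at a limit, > 10000 nM. The same holds for its neighbours, as the limit of > 10000 nM in this assay, at which 3 of the 3 values shown sit, shows, so no measured number fixes its place among them.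

Compound 4 `O=C1C=CC2(C=C1)OCC(=O)N2S(=O)(=O)c1cccs1` has not yet been measured. It differs from compound 2 by thiophen-2-yl in place of 2-methylphenyl on a sulfonyl sulfur.

Among the measured compounds shown here, two measured steps bear on this change. One, a step that the two limits leave unreadable from compound 1 to compound 2, also exchanges the group on the sulfonyl sulfur, so it is the closer precedent. The other, a step that the two limits leave unreadable from compound 2 to compound 3, alters a group on an aromatic carbon. Neither has a readable size, so neither supplies a size or direction to carry over. No step beyond the scatter is therefore expected in this assay, although the data cannot exclude one. For the measured compounds named here, compound 4 is expected to remain weak, and a further limit is the most likely report, because the limit of > 10000 nM in this assay, at which 3 of the 3 values shown sit, describes every measured compound so far. The expected step is a step that the limit leaves unreadable from compound 2 to compound 4. The estimate for compound 4 is 12000 nM, with an expected range from 4000 nM to 30000 nM.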

Compound 4, half-maximal inhibitory concentration: 20 nM
For compound 4 the middle estimate is 600-fold (2.78 log units) above the measured one; the whole stated range lies above it.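

In this assay, thiophen-2-yl in place of 2-methylphenyl on a sulfonyl sulfur gives an at least 500-fold lower number from compound 2 to compound 4 (2.69 log units; beyond the scatter), and thiophen-2-yl in place of methyl at the same place gives an at least 500-fold lower number from compound 1 to compound 4 (2.69 log units; beyond the scatter). The earlier steps shown here could not be read, so only now is it clear that the group on this sulfonyl sulfur, whose other neighbours are: amide-type nitrogen in a ring, can carry a large change in this assay on an otherwise unchanged core, and that an aromatic ring there is not enough by itself, since the 2-methylphenyl of compound 2 does not give a readable value. Compound 4 is the only compound shown with a measured number, and the others give no graded series against which to place it: the limit of > 10000 nM in this assay, at which 3 of the 4 values shown sit.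

The compounds shown do not separate the part played by the sulfur-containing five-membered ring from the loss of the methyl group on the six-membered ring, a question that unsubstituted phenyl or furanyl on the sulfonyl sulfur would bear on. They also leave open how far the result tolerates a substituent such as chlorine or methyl on the thiophene ring.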